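A few compounds are considered here, and "the series" means these few. Any claim that something is new, unique, unknown or untested is made for them only; others in the source may bear on it.

Values in a functional assay on K562 cells (Homo sapiens) for cytotoxicity, read by trypan blue exclusion, with a stated time of 96 h; on this read-out higher numbers stand for weaker inhibition and lower numbers for stronger inhibition
compound 1 `COc1ccccc1/C=C/S(=O)(=O)Cc1ccc(OC)c([N+](=O)[O-])c1` gives 20000 nM
compound 2 `COc1cc(OC)c(/C=C/S(=O)(=O)Cc2ccc(F)c(N)c2)c(OC)c1` gives 2500 nM
compound 3 `COc1ccc(/C=C/S(=O)(=O)Cc2ccc(OC)c([N+](=O)[O-])c2)cc1` gives 25000 nM
compound 4 `COc1ccc(/C=C/S(=O)(=O)Cc2ccc(OC)c(N)c2)cc1` is not yet measured

Compound 3 stands level with compound 1, and compound 2 carries the clearly lower number of the set. The next change gives compound 4, with amino in place of nitro on an aromatic carbon, ortho to a methoxy group (amino in place of nitro on an aromatic carbon). For the measured compounds named here, the one measured step (a 1.3-fold higher number from compound 1 to compound 3 (0.10 log units; within the scatter)) concerns the methoxyphenyl group, not the nitro, and lies within the scatter, so it sets no size for this change. Going by the values given here, no measured pair isolates the exchange of nitro for amino. Among the compounds with values here, the only measured amino compound is compound 2 (2500 nM), which also differs from compound 3 elsewhere, so it is weak support. A move to a lower number in this assay is therefore expected, though with wide uncertainty. The expected step is a 4.2-fold lower number from compound 3 to compound 4 (0.62 log units; beyond the scatter) in this estimate. For compound 4 the estimated value is 6000 nM, with an expected range from 1200 nM to 25000 nM.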

Compound 4, half-maximal inhibitory concentration: 2500 nM
For compound 4 the middle estimate is 2.4-fold (0.38 log units) above the measured one; measured number inside the range.
By their numbers in this assay, from the lowest: compounds 2 and 4 (each within the scatter of the next); then compounds 1 and 3 (each within the scatter of the next).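

In this assay the exchange of nitro for amino, on an aromatic carbon ortho to a methoxy group, gives a 10-fold lower number from compound 3 to compound 4 (1.00 log units; beyond the scatter) and is the first step at this position among the compounds shown. For the compounds shown here, the earlier step of a 1.3-fold higher number from compound 1 to compound 3 (0.10 log units; within the scatter) concerned the methoxyphenyl group and stayed within the scatter, so this is the first single change that clearly moves the number. No measurement at hand bears on why the number moves, and the shift stays unexplained.

Going by these compounds alone, this single pair is the only reading of the position, on the 4-methoxyphenyl background, so it remains open whether the step carries over to the 2-methoxyphenyl background of compound 1. Going by these compounds, how a hydroxyl, an acetamide or a dimethylamino group would read in place of the amino also remains open.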